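This account rests on a few compounds, and the source may have more. Where it says the series, first, only, none or still open, it means among the compounds named here.

Measured in a functional assay on CCRF-CEM cells (Homo sapiens) for cytotoxicity, in the absence of a further agent; on this read-out lower numbers stand for stronger inhibition and higher numbers for weaker inhibition:
compound 1 `COC(=O)c1ccc(CN(CCCc2c(N)nc(N)nc2O)c2cc(F)c(F)cc2[N+](=O)[O-])cc1`: 66000 nM
compound 2 `Nc1nc(N)c(CCCN(Cc2ccc(NC(CCC(=O)O)C(=O)O)cc2)c2cc(F)c(F)cc2[N+](=O)[O-])c(O)n1`: > 100000 nM (a limit)

Compound 2 gives no number, only a limit, with the limit of > 100000 nM in this assay, at which 1 of the 2 values shown sits. Its position therefore has a floor but no fixed value.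

Compound 3 `Nc1nc(N)c(CCCN(Cc2ccc(NC(CCC(=O)O)C(=O)O)cc2)c2ccc([N+](=O)[O-])c(F)c2F)c(O)n1` is the next analogue, with 2,3-difluoro-4-nitrophenyl in place of 4,5-difluoro-2-nitrophenyl on an amine nitrogen. The two have the same atoms, joined differently.

Going by the values given here, only one measured step is available, an at least 1.5-fold higher number from compound 1 to compound 2 (0.18 log units; that floor lies within the scatter), and it comes from (1,3-dicarboxypropyl)amino in place of methoxycarbonyl on an aromatic carbon. That is a different place in the structure, and its floor lies within the scatter, so it bears only indirectly on the new change. Among the compounds with values here, no measured step covers a change of the group on the amine nitrogen. No step beyond the scatter is therefore expected in this assay, and neither direction is favoured.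

A report only as a limit is the likeliest outcome for compound 3. The estimated step is a number no higher from compound 2 to compound 3 (the limit leaves the size open). The expected value for compound 3 is 100000 nM, with an estimated range of 40000 nM to 200000 nM.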

Compound 3, half-maximal inhibitory concentration: > 100000 nM
Compound 3: a limit, no number (the forecaster's own chance of this, stated with the estimate: 70%); the middle value lies on the limit itself.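

In this assay, going by these compounds alone, compound 2 and compound 3 are each reported only as a limit, so no step between them can be read. The compounds shown leave open whether 2,3-difluoro-4-nitrophenyl and 4,5-difluoro-2-nitrophenyl on the amine nitrogen differ at all in this assay, and where either compound's actual value lies.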